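Working notes: amide change from compound 3 to compound 4

This account rests on a few compounds, and the source may have more. Where it says the series, first, only, none or still open, it means among the compounds named here.

Measured so far:
compound 1 `CCOC(=O)Nc1sc(-c2ccc(Cl)cc2)c(-c2ccc(Cl)cc2)c1C(=O)NC1CC1` — 27600 nM
compound 2 `Nc1sc(-c2ccc(Cl)cc2)c(-c2ccc(Cl)cc2)c1C(=O)N1CCNCC1` — 2710 nM
compound 3 `CN1CCN(C(=O)c2c(N)sc(-c3ccc(Cl)cc3)c2-c2ccc(Cl)cc2)CC1` — 13100 nM

In a functional assay on PC-3 cells (Homo sapiens) for inhibition, read by sulforhodamine B assay, with a stated time of 72 h (a higher number here means a weaker inhibitor, a lower number a stronger inhibitor), compound 3 gives 13100 nM, the second highest of the three numbers. The nearest is compound 1 with 27600 nM, a higher number; the furthest is compound 2 with 2710 nM. For the measured compounds named here, the one single-point step in the set, a 4.8-fold higher number from compound 2 to compound 3 (0.68 log units; beyond the scatter), is a modest rise.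

Compound 4 `Nc1sc(-c2ccc(Cl)cc2)c(-c2ccc(Cl)cc2)c1C(=O)NC1CCC1` has not been measured. It differs from compound 3 in one place: cyclobutylamino in place of 4-methylpiperazin-1-yl on a carbonyl carbon. Going by the values given here, no measured step covers this exchange. Compound 1 also carries a cycloalkylamino group on the carbonyl carbon, but it differs from compound 4 in a second place as well, so its value only shows that such an amide can sit at the higher end of the set. Compound 2 shows that a free ring amine gives the lowest number seen. With nothing bearing directly on the change, a step of a 1.1-fold higher number from compound 3 to compound 4 (0.06 log units; within the scatter) is expected, within the scatter. Compound 4 is therefore estimated at 15000 nM, with a range from 4000 nM to 50000 nM.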

Compound 4, half-maximal inhibitory concentration: 24800 nM
For compound 4 the middle estimate is 1.7-fold (0.22 log units) below the measured one, within the range that was stated.
By their numbers in this assay, from the lowest: compound 2; then compounds 3, 4 and 1 (each within the scatter of the next, the first and the last beyond it).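

In this assay the exchange of 4-methylpiperazin-1-yl for cyclobutylamino on a carbonyl carbon gives a 1.9-fold higher number from compound 3 to compound 4 (0.28 log units; within the scatter) and so does not separate these two amides, although the two groups differ in ring size and in hydrogen-bond donor count. Cyclobutylamino in place of piperazin-1-yl gives a 9.2-fold higher number from compound 2 to compound 4 (0.96 log units; beyond the scatter) at the same carbonyl carbon, so among the three compounds that differ only here, the low number stays with the piperazin-1-yl amide of compound 2. Nothing measured on these compounds accounts for either step.

From the compounds shown here alone, it remains open whether another ring amine on this carbonyl carbon, such as a homopiperazine, would stay with compound 2 or fall with compound 3 and compound 4. An open-chain aminoethylamino group would test whether the ring itself is needed to keep the lower number.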